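Series notes: pyridin-3-yl ether replacing ethyl ether

A few compounds are considered here, and "the series" means these few. Any claim that something is new, unique, unknown or untested is made for them only; others in the source may bear on it.

Measured so far:
- compound 1, `CCOc1ccc(Cl)c(-c2ccc(OCCCC(=O)O)cc2)c1`: 1130 nM
- compound 2, `O=C(O)CCCOc1ccc(-c2cc(OC(F)(F)F)ccc2F)cc1`: 4220 nM

Two compounds have been run in a functional assay on isolated protein for agonist activity at Free fatty acid receptor 1 (Homo sapiens), read by HTRF and inositol phosphate accumulation, with a stated time of 60 min; a lower number here means that less compound is needed, a higher number that more compound is needed for the effect. Compound 1 gives 1130 nM and stands as the lower of the two numbers. Compound 2 gives 4220 nM; the gap between compound 2 and compound 1 lies beyond the usual scatter, so compound 1 is the stronger of the pair on what has been seen. Going by the values given here, no pair of measured compounds differs in a single place, so no single-change step is available as a guide.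

The next compound, compound 3, `O=C(O)CCCOc1ccc(-c2cc(Oc3cccnc3)ccc2Cl)cc1`, keeps the shared core of compound 1 and alters one group: pyridin-3-yl in place of ethyl on an oxygen on an aromatic ring. The acid chain and the chlorine of compound 1 are retained.

Among the compounds with values here, with no measured step of this kind to lean on, the expectation rests on the value of compound 1 alone. For compound 3 the step of a 2.3-fold lower number from compound 1 to compound 3 (0.35 log units; beyond the scatter) is estimated to lie toward a lower number, of a size at the edge of the scatter rather than clearly beyond it. Compound 3 is expected at 500 nM, within a range from 150 nM to 2000 nM.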

Compound 3, half-maximal effective concentration: > 9950 nM
Compound 3 gave a limit, no number; the forecaster's own chance of this, stated with the estimate: 5%; middle value at least 19-fold (1.29 log units) from the limit.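

In this assay compound 3 gives > 9950 nM, a limit of the assay and not a number. Going by these compounds alone, as the only single-change step so far, pyridin-3-yl in place of ethyl on an oxygen on an aromatic ring gives an at least 8.8-fold higher number from compound 1 to compound 3 (0.94 log units; beyond the scatter), so this position does not accept every replacement of ethyl, and the retained acid chain and chlorine do not by themselves hold the activity. The full size of the step stays unfixed, and only its lower bound can be read: the limit of > 9950 nM in this assay, at which 1 of the 3 values shown sits.

The compounds shown do not separate the effect of the added ring from that of its nitrogen, and a phenyl on the same oxygen would be the direct comparison with compound 3. As far as these compounds go, it also remains open how this position responds to groups closer to ethyl, such as methyl or a longer propyl chain, and whether pyridin-2-yl or pyridin-4-yl would behave as pyridin-3-yl does here.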